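The source may report more compounds than this note shows. Statements on the series, on what has been measured and on what is new or still open speak of the compounds shown alone.

Series notes, ester series, measured in a functional assay on HL-60 cells (Homo sapiens) for cytotoxicity, read by MTT assay, with a stated time of 72 h; a higher number here means a weaker inhibitor, a lower number a stronger inhibitor:

compound 1 `CC1=CC[C@]2(C)[C@@H]([C@@H](OC(=O)c3ccc(O)cc3)C1)[C@](O)(C(C)C)C[C@@H]2O` gives 3500 nM
compound 2 `COc1ccc(C(=O)O[C@H]2CC(C)=CC[C@@]3(C)CC[C@@](O)(C(C)C)[C@H]23)cc1` gives 20100 nM

Compound 2 stands at the highest of the two numbers, and compound 1 is the nearest to it, the gap between them being beyond the scatter. The two differ in more than one place, so their values can only be read as a pair and not as a single step.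

Compound 3 `CC1=CC[C@@]2(C)CC[C@@](O)(C(C)C)[C@@H]2[C@@H](OC(=O)c2ccc(O)cc2)C1` is the next compound to be measured. It differs from compound 2 in one place: hydrogen in place of methyl on an oxygen on an aromatic ring. The same change, read one bond further out, is methoxy to hydroxy, so the aryl ester of compound 3 carries the 4-hydroxyphenyl group that compound 1 also carries, while the core of compound 3 is that of compound 2.

Going by the values given here, no measured pair gives this change on its own. With compound 1 at 3500 nM and compound 2 at 20100 nM, the direction towards a lower number is expected for compound 3, with a step of moderate size: a 2.5-fold lower number from compound 2 to compound 3 (0.40 log units; beyond the scatter) is the expected step in this assay. Compound 3 is estimated at 8000 nM, within 3000 nM to 21000 nM.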

Compound 3, half-maximal inhibitory concentration: > 100000 nM
Compound 3: no number, only a limit; the forecaster's own chance of this, stated with the estimate: 3%; middle value at least 12-fold (1.09 log units) away from the limit.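

In this assay compound 3 gives > 100000 nM, which is a limit of the assay and not a number. Methoxy to hydroxy on the aromatic ring of the ester is not a silent change on this core: it gives an at least 4.9-fold higher number from compound 2 to compound 3 (0.69 log units; beyond the scatter), so the 4-methoxyphenyl ester keeps a measured value while the 4-hydroxyphenyl ester only reaches a limit. The 4-hydroxyphenyl group alone therefore does not secure a measured value, and hydrogen in place of hydroxy on a saturated ring carbon gives an at least 28-fold higher number from compound 1 to compound 3 (1.45 log units; beyond the scatter), with both steps bounded on one side only: the limit of > 100000 nM in this assay, at which 1 of the 3 values shown sits.

From the compounds shown here alone, how methoxy to hydroxy reads on the core of compound 1 remains open; only the 4-hydroxyphenyl ester stands on that core here. Also open, going by these compounds, are the true sizes of both steps and what an amine or a carboxylic acid on the aromatic ring, or a longer chain in place of the methyl on the oxygen, would give in this assay.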